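A few compounds are considered here, and "the series" means these few. Any claim that something is new, unique, unknown or untested is made for them only; others in the source may bear on it.

Among the compounds with values here, in a functional assay on CCRF-CEM cells (Homo sapiens) for cytotoxicity, in the absence of a further agent (on this read-out lower numbers stand for stronger inhibition and higher numbers for weaker inhibition), compound 2 (`CC(C)(C)OC(=O)CCC(Nc1ccc(CN(CCCc2c(N)nc(N)nc2O)c2ccc([N+](=O)[O-])c(F)c2F)cc1)C(=O)OC(C)(C)C`) gives 24000 nM, the higher of the two numbers so far, while compound 1 (`CC(C)(C)OC(=O)CCC(Nc1ccc(CN(CCCc2c(N)nc(N)nc2O)c2cc(F)ccc2[N+](=O)[O-])cc1)C(=O)OC(C)(C)C`) gives 8700 nM. Compound 3 (`CC(C)(C)OC(=O)CCC(Nc1ccc(CN(CCCc2c(N)nc(N)nc2O)c2cc(F)c(F)cc2[N+](=O)[O-])cc1)C(=O)OC(C)(C)C`) differs from compound 2 by one change: 4,5-difluoro-2-nitrophenyl in place of 2,3-difluoro-4-nitrophenyl on an amine nitrogen. Within the data shown here, the only measured step that bears on this is a 2.8-fold higher number from compound 1 to compound 2 (0.44 log units; beyond the scatter), a modest one. The entering group more closely resembles that of compound 1, so a step of similar size toward a lower number is expected in this assay. The estimated change is a 2.2-fold lower number from compound 2 to compound 3 (0.34 log units; beyond the scatter). The expected value for compound 3 is 11000 nM, within an estimated range of 4500 nM to 26000 nM.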

Compound 3, half-maximal inhibitory concentration: 4800 nM
The estimate for compound 3 lay 2.3-fold (0.36 log units) above the measured number; the range from low to high includes it.
By their numbers in this assay, from the lowest: compounds 3 and 1 (each within the scatter of the next); then compound 2.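

In this assay, the arrangement of the same atoms counts at this amine nitrogen: 4,5-difluoro-2-nitrophenyl in place of 2,3-difluoro-4-nitrophenyl gives a 5.0-fold lower number from compound 2 to compound 3 (0.70 log units; beyond the scatter) for groups of identical atom count. Fluoro in place of hydrogen on an aromatic carbon gives a 1.8-fold lower number from compound 1 to compound 3 (0.26 log units; within the scatter) and so does not separate these two compounds. Nothing measured here accounts for the difference between the two arrangements. From the compounds shown here alone, whether a carboxylic acid in place of the tert-butyl esters, or an amine in place of the nitro group, would shift the number in this assay remains open.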